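Methoxy in place of chloro on a kinase-type amide scaffold

This account rests on a few compounds, and the source may have more. Where it says the series, first, only, none or still open, it means among the compounds named here.

Measured compounds:
- compound 1 `COc1cccc(-c2cc(C(=O)Nc3ccc(Oc4ccnc5cc(OCCCN6CCCCC6)c(OC)cc45)c(F)c3)c3cc(F)ccc3n2)c1`: 2500 nM
- compound 2 `COc1cc2c(Oc3ccc(NC(=O)c4cc(-c5cccc(Cl)c5)nc5ccc(F)cc45)cc3F)ccnc2cc1OCCCN1CCC(C)CC1`: 92 nM

In a functional assay on HT-29 cells (Homo sapiens) for cytotoxicity, read by MTT assay, with a stated time of 72 h (on this read-out lower numbers stand for stronger inhibition and higher numbers for weaker inhibition), compound 2 gives 92 nM, the lowest number of the two, while compound 1 gives 2500 nM, a gap well beyond the scatter. Within the data shown here, the two differ in more than one place, so no single-point step links them. Compound 3 `COc1cccc(-c2cc(C(=O)Nc3ccc(Oc4ccnc5cc(OCCCN6CCC(C)CC6)c(OC)cc45)c(F)c3)c3cc(F)ccc3n2)c1` keeps the whole of compound 2 except for one change: methoxy in place of chloro on an aromatic carbon. Compound 1 also carries a 3-methoxyphenyl group and is much weaker, yet its other differences leave the cause open. The estimated step in this assay is therefore a 4.3-fold higher number from compound 2 to compound 3 (0.64 log units; beyond the scatter), an upward step that stays smaller than the full gap to compound 1. Compound 3 is estimated at 400 nM, with a range from 100 nM to 2000 nM.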

Compound 3, half-maximal inhibitory concentration: 1210 nM
Compound 3: the middle estimate sits 3.0-fold (0.48 log units) below what was measured; the range from low to high includes it.
By their numbers in this assay, from the lowest: compound 2; then compound 3; then compound 1.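

Changing 3-chlorophenyl to 3-methoxyphenyl, with nothing else altered, gives a 13-fold higher number from compound 2 to compound 3 (1.12 log units; beyond the scatter) in this assay, so the group at this place on the aromatic ring strongly affects the read-out. Among these compounds, compound 3 also links compound 1 to the series through one change on the saturated ring, methyl in place of hydrogen, and that gives a 2.1-fold lower number from compound 1 to compound 3 (0.32 log units; beyond the scatter), a modest step that is much smaller than the one from the aromatic swap. Nothing measured here gives a cause for either step.

Still open, on these data alone, is how other groups at the same aromatic position, such as fluoro, methyl or a nitrile, would compare with chloro and methoxy. As far as these compounds go, it is also open whether the ring methyl would give a step of similar size in a compound carrying 3-chlorophenyl.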